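A few compounds are considered here, and "the series" means these few. Any claim that something is new, unique, unknown or untested is made for them only; others in the source may bear on it.

Compound 1 `Cn1ccc2cc(-c3ccc4oc(Nc5ccccn5)nc4c3)ccc21`: 186 nM
Compound 2 `Cn1ccc2cc(-c3ccc4oc(Nc5cccnc5)nc4c3)ccc21`: 226 nM

Both compounds were tested in an assay on HEK293 cells for inhibition of Fatty-acid amide hydrolase 1 (Homo sapiens), read by fluorescence; a lower number here means a stronger inhibitor, a higher number a weaker inhibitor. Among the measured compounds shown here, compound 2 stands beside compound 1 within the scatter: the only measured step, a 1.2-fold higher number from compound 1 to compound 2 (0.08 log units; within the scatter), swaps one pyridyl isomer for another on the amino nitrogen and changes the number by less than the usual spread of repeat measurements.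

Compound 3 `Cn1ccc2cc(-c3ccc4oc(N5CCn6cccc6C5)nc4c3)ccc21` has not yet been measured. Its difference from compound 2 is a group of 9 heavy atoms (7 carbon, 2 nitrogen; one five-membered aromatic ring with 1 hetero atom, one six-membered non-aromatic ring with 2 hetero atoms) in place of a group of 7 heavy atoms (5 carbon, 2 nitrogen; one six-membered aromatic ring with 1 hetero atom), on an aromatic carbon. The whole (pyridin-3-yl)amino group, with its single hydrogen-bond donor, is replaced by a fused two-ring amine that carries no donor.

For the measured compounds named here, no measured step bears directly on this change. The step of a 1.2-fold higher number from compound 1 to compound 2 (0.08 log units; within the scatter) only tells that moving the ring nitrogen within the pyridyl ring does not matter, and says nothing about removing the donor or enlarging the group. The direction of the expected step is therefore open, and a wide range is appropriate.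

Compound 3 is estimated at 450 nM, within 120 nM to 2000 nM. That estimate corresponds to an expected step of a 2.0-fold higher number from compound 2 to compound 3 (0.30 log units; within the scatter).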

Compound 3, half-maximal inhibitory concentration: 42 nM
Estimate against measurement, compound 3: 11-fold (1.03 log units) above; the whole stated range lies above it.
By their numbers in this assay, from the lowest: compound 3; then compounds 1 and 2 (each within the scatter of the next).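

At this position, on an aromatic carbon next to the ring nitrogen and next to the ring oxygen, the number in this assay can move well beyond the scatter, which the swap between pyridyl isomers did not show. Replacing the (pyridin-3-yl)amino group with the fused two-ring amine gives a 5.4-fold lower number from compound 2 to compound 3 (0.73 log units; beyond the scatter), and the same kind of replacement starting from the pyridin-2-yl compound gives a 4.4-fold lower number from compound 1 to compound 3 (0.65 log units; beyond the scatter), so compound 3 is the strongest inhibitor of the three, and a group with 0 hydrogen-bond donors is compatible with this stronger result. No measurement shown here accounts for the gain in strength.

The compounds shown do not separate the loss of the amino hydrogen from the change of ring system, a question that a methyl group on the amino nitrogen of the (pyridin-3-yl)amino group could address. They also leave open whether the five-membered aromatic ring of the entering group matters, or whether a plain piperidine or morpholine ring at this position would give a similar number.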